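A few compounds are considered here, and "the series" means these few. Any claim that something is new, unique, unknown or untested is made for them only; others in the source may bear on it.

Measured compounds in a functional assay on the whole organism (strain STD-dd) with Mus musculus as the target, in the maximal electroshock model, with a stated time of 2 h; a higher number here means that more compound is needed for the effect, a lower number that less compound is needed:

- compound 1, `CN(C)S(=O)(=O)Cc1noc2ccc(F)cc12`, gives 32 mg/kg
- compound 2, `NS(=O)(=O)Cc1noc2ccc(Br)cc12`, gives 14 mg/kg
- compound 3, `CCNS(=O)(=O)Cc1noc2ccc(Br)cc12`, gives 18 mg/kg

All three share the same core and differ only in the group on the sulfonamide nitrogen and in the halogen on the ring. Among the three numbers, compound 3 stands in the middle: its value lies close to that of compound 2 and somewhat further from that of compound 1, but both gaps are within the usual scatter, so no ordering can be read from them.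

The next compound, compound 4, `CN(C)S(=O)(=O)Cc1noc2ccc(Br)cc12`, keeps the halogen of compound 3 and changes only the sulfonamide: dimethylamino in place of ethylamino on a sulfonyl sulfur.

Within the data shown here, only one measured step touches the sulfonamide nitrogen. It is a 1.3-fold higher number from compound 2 to compound 3 (0.11 log units; within the scatter), a change that stayed within the scatter. Compound 1 carries the same dimethylamino group as compound 4, though with a different halogen, and its value sits within the scatter of compound 3 as well. The step from compound 3 to compound 4 is therefore expected to be small, a 1.2-fold higher number from compound 3 to compound 4 (0.09 log units; within the scatter), with no clear direction beyond the scatter. Compound 4 is estimated to give 22 mg/kg, in a range from 11 mg/kg to 45 mg/kg.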

Compound 4, dose for half-maximal effect: 45 mg/kg
For compound 4 the middle estimate is 2.0-fold (0.31 log units) below the measured one; the range from low to high includes it.
By their numbers in this assay, from the lowest: compounds 2, 3, 1 and 4 (each within the scatter of the next, the first and the last beyond it).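

In this assay the group on the sulfonyl sulfur now makes a readable difference: dimethylamino in place of ethylamino gives a 2.5-fold higher number from compound 3 to compound 4 (0.40 log units; beyond the scatter) and dimethylamino in place of amino gives a 3.2-fold higher number from compound 2 to compound 4 (0.51 log units; beyond the scatter) while the earlier step from amino to ethylamino stayed within the scatter. Ethylamino and dimethylamino count the same heavy atoms and differ in that ethylamino carries a hydrogen-bond donor and dimethylamino none, whereas the change on the aromatic carbon, bromo in place of fluoro, gives a 1.4-fold higher number from compound 1 to compound 4 (0.15 log units; within the scatter) and so shows no clear effect of the halogen with dimethylamino in place. No measurement shown here explains why the two isomeric groups differ in this whole-animal test.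

Methylamino on the same sulfur, which would pair a single methyl with a remaining hydrogen on the nitrogen, could help separate the loss of that hydrogen from the presence of a second carbon on the nitrogen. From the compounds shown here alone, how a ring on the nitrogen, such as pyrrolidine, or a chloro group on the aromatic carbon would fit this picture also remains open.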